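The compounds below may be only part of what the source reports. "The series", "measured", "known", "first", "only" and "open" are said of these compounds alone.

Measured so far: compound 1 `c1ccc2c(c1)CN[C@@H](CN(CCCN1CCNCC1)[C@H]1CCCc3cccnc31)C2` with 17 nM in a functional assay on CCRF-CEM cells for antagonist activity at C-X-C chemokine receptor type 4 (Homo sapiens), read by calcium flux, with stated times of 25 min and 90 s; on this read-out higher numbers stand for weaker inhibition and lower numbers for stronger inhibition; compound 2 `c1cnc2c(c1)CN[C@H](CN(CCCN1CCNCC1)[C@H]1CCCc3cccnc31)C2` with 2640 nM in this assay.

Compound 2 gives the highest of the two numbers; the nearest is compound 1, reached by a 160-fold higher number from compound 1 to compound 2 (2.19 log units; beyond the scatter).

Compound 3 `c1cnc2c(c1)CN[C@@H](CN(CCCN1CCNCC1)[C@H]1CCCc3cccnc31)C2` differs from compound 2 by the two compounds have the same atoms and bonds and differ only in configuration as drawn: 1 of 2 stereo elements differ; a stereocentre at a saturated ring carbon is drawn S in compound 2 and R in compound 3. Among the measured compounds shown here, the only measured step, a 160-fold higher number from compound 1 to compound 2 (2.19 log units; beyond the scatter), concerns a ring exchange and not a configuration, so no step bears on this change. With nothing to anchor it, the expected step of a 1.8-fold lower number from compound 2 to compound 3 (0.25 log units; within the scatter) is taken as none beyond the scatter, with a wide range. Compound 3 is therefore estimated at 1500 nM, between 150 nM and 8000 nM, in this assay.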

Compound 3, half-maximal inhibitory concentration: 171 nM
Estimate against measurement, compound 3: 8.8-fold (0.94 log units) above; measured number inside the range.
By their numbers in this assay, from the lowest: compound 1; then compound 3; then compound 2.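

At this position the configuration matters, not just the ring exchange: a 15-fold lower number from compound 2 to compound 3 (1.19 log units; beyond the scatter) in this assay, with no atom or bond changed. That step can be put down to the stereocentre alone: the fact that compounds 2 and 3 differ only in the configuration as drawn. With the drawn configuration of compound 1 kept, the ring exchange still leaves a 10-fold higher number from compound 1 to compound 3 (1.00 log units; beyond the scatter), so the exchange and the configuration each shift the number.

Open, as far as these compounds go, is whether the configuration matters as much with the aromatic ring of carbon only, as in compound 1. Also open, from the compounds shown here alone, is how a fluorine or methoxy group on that aromatic ring would read in this assay.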